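Swapping the anilide aryl group within the phenyl-bearing series

The source may hold more compounds than are shown below. What is called first, only, known or untested is meant among the compounds shown, and "the series" means these compounds.

Compound 1 `Cc1cccc(Cl)c1NC(=O)CN1CCN(c2nnc(Cc3ccncc3)c3ccccc23)CC1` gives 7190 nM in a functional assay on A549 cells (Homo sapiens) for cytotoxicity, read by MTT assay, with a stated time of 72 h; on this read-out lower numbers stand for stronger inhibition and higher numbers for weaker inhibition.
Compound 2 `O=C(CN1CCN(c2nnc(Cc3ccccc3)c3ccccc23)CC1)Nc1ccc(F)c(C(F)(F)F)c1` gives 2480 nM in this assay.
Compound 3 `O=C(CN1CCN(c2nnc(Cc3ccncc3)c3ccccc23)CC1)Nc1ccc(F)c(C(F)(F)F)c1` gives 16000 nM in this assay.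

Compound 2 holds the lowest of the three numbers in this assay; compound 1 lies nearest to it and compound 3 furthest, both gaps beyond the scatter. Compound 4 `Cc1cccc(Cl)c1NC(=O)CN1CCN(c2nnc(Cc3ccccc3)c3ccccc23)CC1` differs from compound 2 in one place: 2-chloro-6-methylphenyl in place of 4-fluoro-3-(trifluoromethyl)phenyl on an amide-type nitrogen. Within the data shown here, the one measured step that bears on this change is a 2.2-fold higher number from compound 1 to compound 3 (0.35 log units; beyond the scatter), the same exchange run in the opposite direction on the pair carrying pyridin-4-yl. Turning that step around, a modest fall in the number is expected for compound 4, a 2.1-fold lower number from compound 2 to compound 4 (0.32 log units; beyond the scatter). Compound 4 is therefore estimated at 1200 nM, with a range from 500 nM to 3500 nM.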

Compound 4, half-maximal inhibitory concentration: 7420 nM
Beside the measured number, compound 4's estimate is 6.2-fold (0.79 log units) below it; measured number above the stated range.
By their numbers in this assay, from the lowest: compound 2; then compounds 1 and 4 (each within the scatter of the next); then compound 3.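

In this assay the aryl exchange on the amide-type nitrogen depends on the group at the other end of the molecule: with phenyl in place of pyridin-4-yl, 2-chloro-6-methylphenyl gives a 3.0-fold higher number from compound 2 to compound 4 (0.48 log units; beyond the scatter) and so runs against the direction seen in the pyridin-4-yl pair: the same change on two cores in this assay, a 2.2-fold higher number (0.35 log units; beyond the scatter) from compound 1 to compound 3 and a 3.0-fold lower number (0.48 log units; beyond the scatter) from compound 4 to compound 2, 6.7-fold (0.82 log units) apart, beyond the scatter of two such steps. Phenyl in place of pyridin-4-yl gives a 1.0-fold higher number from compound 1 to compound 4 (0.01 log units; within the scatter) when 2-chloro-6-methylphenyl is present, so that change also depends on its partner: the same change on two cores in this assay, a 6.5-fold higher number (0.81 log units; beyond the scatter) from compound 2 to compound 3 and a 1.0-fold lower number (0.01 log units; within the scatter) from compound 4 to compound 1, 6.7-fold (0.82 log units) apart, beyond the scatter of two such steps.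

From the compounds shown here alone, whether this dependence extends beyond these four pairings remains open. An unsubstituted phenyl or 4-methoxyphenyl on the amide-type nitrogen, or a pyrimidin-5-yl on the chain carbon, would test it.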